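Moving the two fluorines on the benzyl group

The source may report more compounds than this note shows. Statements on the series, on what has been measured and on what is new or still open speak of the compounds shown alone.

Compound 1 `CC1(C)c2[nH]nc(NC(=O)c3ccccc3)c2CN1Cc1cc(F)cc(F)c1` gives 190 nM in an assay on Sf21 cells for inhibition of high affinity nerve growth factor receptor (Homo sapiens), read by HTRF, with a stated time of 30 min, in the presence of a further agent that is not named here; a lower number here means a stronger inhibitor, a higher number a weaker inhibitor. Compound 2 `CC1(C)c2[nH]nc(NC(=O)c3ccc(Br)cc3)c2CN1Cc1cccc(F)c1F` gives 950 nM in this assay, the higher of the two numbers, and its gap to compound 1 lies beyond the usual scatter. Compound 3 `CC1(C)c2[nH]nc(NC(=O)c3ccc(Br)cc3)c2CN1Cc1cc(F)cc(F)c1` differs from compound 2 by 3,5-difluorophenyl in place of 2,3-difluorophenyl on a saturated chain carbon bound to an amine nitrogen in a ring. Within the data shown here, no measured pair isolates this change, because compound 1 also carries a different benzoyl ring, so the expectation rests on a partial comparison. A step of a 2.4-fold lower number from compound 2 to compound 3 (0.38 log units; beyond the scatter) toward a lower number is expected. Compound 3 is estimated at 400 nM, with a likely range from 150 nM to 1200 nM.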

Compound 3, half-maximal inhibitory concentration: 710 nM
Estimate against measurement, compound 3: 1.8-fold (0.25 log units) below, and the stated range covers the measured number.
By their numbers in this assay, from the lowest: compound 1; then compounds 3 and 2 (each within the scatter of the next).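

With the bromo on the benzoyl ring kept, 3,5-difluorophenyl in place of 2,3-difluorophenyl gives a 1.3-fold lower number from compound 2 to compound 3 (0.13 log units; within the scatter) in this assay and so does not separate the two fluorine patterns. Among these compounds, with 3,5-difluorobenzyl kept, bromo in place of hydrogen on an aromatic carbon gives a 3.7-fold higher number from compound 1 to compound 3 (0.57 log units; beyond the scatter) and is the only single change here that clears the scatter. Nothing measured here explains either step.

As far as these compounds go, whether 2,3-difluorobenzyl behaves the same on the benzoyl ring without bromo stays open. So does what a chloro or a methoxy group would give in place of bromo.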